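Oxazole for furan in a histamine H3 amide series

The compounds below may be only part of what the source reports. "The series", "measured", "known", "first", "only" and "open" are said of these compounds alone.

Measured compounds:
compound 1 `Cc1cc(N2CC[C@H](N3CCC[C@@H]3C)C2)ccc1NC(=O)c1ccoc1`, 1.8 nM
compound 2 `Cc1nc(N2CC[C@H](N3CCC[C@@H]3C)C2)ccc1NC(=O)c1ccccc1`, 3 nM

In an assay on CHO cells for displacement of a labelled ligand from histamine receptor H3 (Macaca mulatta), read by scintillation counting, with a stated time of 1 h (on this read-out lower numbers stand for stronger inhibition and higher numbers for weaker inhibition), compound 1 gives 1.8 nM. Compound 2, which shares the pyrrolidinyl-piperidine amide core, gives 3 nM in this assay; the two numbers lie within the usual scatter of each other, so neither compound can be ranked ahead of the other. Compound 3 `Cc1nc(C(=O)Nc2ccc(N3CC[C@H](N4CCC[C@@H]4C)C3)cc2C)co1` differs from compound 1 by 2-methyl-1,3-oxazol-4-yl in place of furan-3-yl on a carbonyl carbon. Among the measured compounds shown here, no measured pair shows this exchange, so the step is estimated: one five-membered heteroaryl amide replaces another, and the expected change from compound 1 to compound 3 is a 1.7-fold higher number from compound 1 to compound 3 (0.22 log units; within the scatter), about none beyond the scatter. Compound 3 is therefore expected to give 3 nM, within 1 nM to 10 nM.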

Compound 3, inhibition constant: 4.6 nM
Beside the measured number, compound 3's estimate is 1.5-fold (0.19 log units) below it; the range from low to high includes it.
By their numbers in this assay, from the lowest: compounds 1, 2 and 3 (each within the scatter of the next, the first and the last beyond it).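

In this assay, among the compounds shown here, the first measured step at this position is a 2.6-fold higher number from compound 1 to compound 3 (0.41 log units; beyond the scatter), on exchanging furan-3-yl for 2-methyl-1,3-oxazol-4-yl on a carbonyl carbon. The step is modest, so this position accepts a five-membered aromatic ring with an added ring nitrogen and methyl at only a limited cost in binding. No available evidence bears on the reason for this step. The contributions of the ring nitrogen and the methyl remain inseparable here. Going by these compounds, how an unsubstituted 1,3-oxazol-4-yl or a thiophen-3-yl would compare at this carbonyl remains open.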